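The compounds below may be only part of what the source reports. "The series", "measured", "known", "first", "only" and "open" are said of these compounds alone.

Values in a functional assay on MCF7 cells (Homo sapiens) for inhibition, read by MTT assay, with a stated time of 48 h, tested at 10 uM; on this read-out higher numbers stand for more inhibition of growth at the one concentration tested and lower numbers for less inhibition of growth:

Compound 1 `Cc1oc2c([C@H]3CCN(C)C[C@H]3O)c(O)cc(O)c2c(=O)c1C(O)c1ccc(Cl)cc1` gives 6%
Compound 2 `Cc1oc2c([C@H]3CCN(C)C[C@H]3O)c(O)cc(O)c2c(=O)c1C(O)c1c(Cl)cccc1Cl` gives 33%
Compound 3 `Cc1oc2c([C@H]3CCN(C)C[C@H]3O)c(O)cc(O)c2c(=O)c1C(O)c1c(F)cccc1Cl` gives 41%

Compound 3 has one close neighbour and one distant one on this scale. The small gap is a number 8 percentage points higher from compound 2 to compound 3 (within the scatter), and the wide gap is a number 35 percentage points higher from compound 1 to compound 3 (beyond the scatter).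

Compound 4 `CCOc1ccc(Br)c(C(O)c2c(C)oc3c([C@H]4CCN(C)C[C@H]4O)c(O)cc(O)c3c2=O)c1` alters only the aromatic group: 2-bromo-5-ethoxyphenyl in place of 2-chloro-6-fluorophenyl on a saturated chain carbon bound to an aromatic carbon and an oxygen on a saturated carbon. The closest guide is the other step that alters this group, a number 27 percentage points higher from compound 1 to compound 2 (beyond the scatter), which shows that the group can move the number considerably. Compounds 2 and 3 each carry two halogens on this ring, while compound 1 carries a single chloro. For the measured compounds named here, compound 4 also carries a single halogen, a bromo, together with an ethoxy group, and no measured compound has either of these. A result somewhat under compound 3 and still clear of compound 1 therefore seems most likely, though with wide uncertainty. The expected change is a number 11 percentage points lower from compound 3 to compound 4 (beyond the scatter), a modest fall. For compound 4 the estimated value is 30%, with an expected range from 10% to 52%.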

Compound 4, percent growth inhibition at one concentration: 9%
Beside the measured number, compound 4's estimate is 21 percentage points above it, and the stated range ends above it.
By their numbers in this assay, from the lowest: compounds 1 and 4 (each within the scatter of the next); then compounds 2 and 3 (each within the scatter of the next).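

In this assay, the aromatic group at this place can take the number down as well as up: 2-bromo-5-ethoxyphenyl gives a number 32 percentage points lower from compound 3 to compound 4 (beyond the scatter) and a number 24 percentage points lower from compound 2 to compound 4 (beyond the scatter), yet only a number 3 percentage points higher from compound 1 to compound 4 (within the scatter). Among these four compounds, the two rings with two halogens, in compound 2 and compound 3, give the higher numbers and the two rings with one halogen, in compound 1 and compound 4, give the lower numbers, with no compound going against this, although the ring of compound 4 also carries an ethoxy group. Nothing available here explains these differences.

The compounds shown do not separate the bromo from the ethoxy, which a phenyl ring carrying only one of them could do. On these data alone, how an amine or a carboxylic acid on this ring would read also stays open.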